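Aryl ether to aryl thioether on a shared core

The source may report more compounds than this note shows. Statements on the series, on what has been measured and on what is new or still open speak of the compounds shown alone.

In a functional assay on K562 cells (Homo sapiens) for inhibition, read by sulforhodamine B assay, with a stated time of 48 h (a higher number here means that more compound is tolerated, a lower number that less compound is tolerated), compound 1 `Nc1cc(N)c2nc(-c3ccccc3)c(Oc3ccc(Cl)c(Cl)c3)nc2c1` gives < 100000 nM, which is a limit of the assay rather than a number. Compound 2 `CCOC(=O)[C@H](CCC(=O)O)NC(=O)c1ccc(CNc2nc3cc(N)cc(N)c3nc2-c2ccccc2)cc1` gives < 100000 nM, again a limit. For the measured compounds named here, both values sit at the limit of < 100000 nM in this assay, at which 2 of the 2 values shown sit, so no ranking within the pair is possible. Compound 3 `Nc1cc(N)c2nc(-c3ccccc3)c(Sc3ccc(F)cc3)nc2c1` differs from compound 1 by (4-fluorophenyl)sulfanyl in place of 3,4-dichlorophenoxy on an aromatic carbon. Going by the values given here, no step between measured compounds has been quantified, and no direction can be read from the data. The step is expected to stay within the usual scatter, a step that the limit leaves unreadable from compound 1 to compound 3. Compound 3 is expected to give 20000 nM, with a range from 3000 nM to 90000 nM, and a fair chance that only a limit is reported once more.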

Compound 3, concentration lethal to 50% of the cells: < 100000 nM
Compound 3 was reported as a limit; the forecaster's own chance of this, stated with the estimate: 60%; the middle value lies beyond the limit too.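

Compound 1 and compound 3 are both reported only as limits, so no step can be read between them: the limit of < 100000 nM in this assay, at which 3 of the 3 values shown sit.

On these data alone, whether (4-fluorophenyl)sulfanyl in place of 3,4-dichlorophenoxy on the shared core shifts the read-out at all remains open.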